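The source may hold more compounds than are shown below. What is called first, only, known or untested is meant among the compounds shown, and "the series" means these compounds.

Working notes on the series. Compound 1 `COc1cc(-c2nnc(SCC(=O)c3ccccc3)n2N)cc(OC)c1OC` carries the shared core with a benzoyl group on the sulfur-linked chain. In a functional assay on HeLa cells (Homo sapiens) for antiproliferative activity, read by MTT assay, with a stated time of 48 h (a higher number here means a weaker inhibitor, a lower number a stronger inhibitor), compound 1 returns only a limit, > 100000 nM, so its standing on the scale is open; the reading sits at the limit of > 100000 nM in this assay, at which 1 of the 3 values shown sits. Compound 2 `COc1cc(-c2nnc(SCC(=O)c3ccc(C)cc3)n2N)cc(OC)c1OC`, methyl in place of hydrogen on an aromatic carbon, gives 2940 nM in this assay. Compound 3 `COc1cc(-c2nnc(SCC(=O)c3ccccc3F)n2N)cc(OC)c1OC`, fluoro in place of hydrogen on an aromatic carbon, gives 80100 nM in this assay. The measured steps read an at least 34-fold lower number from compound 1 to compound 2 (1.53 log units; beyond the scatter), an at least 1.2-fold lower number from compound 1 to compound 3 (0.09 log units; that floor lies within the scatter) and a 27-fold higher number from compound 2 to compound 3 (1.44 log units; beyond the scatter).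

Compound 4 `COc1cc(-c2nnc(SCC(=O)Nc3ccccc3C)n2N)cc(OC)c1OC` is not yet measured in this assay. Against compound 1 the change is (2-methylphenyl)amino in place of phenyl on a carbonyl carbon. Among the compounds with values here, no measured step covers an amino group entering at the carbonyl carbon. Within the data shown here, the only related step is the methyl added on an aromatic carbon from compound 1 to compound 2, which was large, an at least 34-fold lower number from compound 1 to compound 2 (1.53 log units; beyond the scatter); the fluoro step an at least 1.2-fold lower number from compound 1 to compound 3 (0.09 log units; that floor lies within the scatter) stayed within the scatter. The expected step is therefore a lowering, an at least 5.0-fold lower number from compound 1 to compound 4 (0.69 log units; beyond the scatter), but it is estimated with wide uncertainty because compound 1 gives only the limit > 100000 nM. Compound 4 is thus expected at 20000 nM, within 2000 nM to 150000 nM.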

Compound 4, half-maximal inhibitory concentration: > 100000 nM
Compound 4: only a limit was reported; the forecaster's own chance of this, stated with the estimate: 35%; at least 5.0-fold (0.69 log units) between middle value and limit.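

Compound 4 stands at a limit of the assay, as compound 1 does, so the step between them cannot be read: the limit of > 100000 nM in this assay, at which 2 of the 4 values shown sit.

Placing (2-methylphenyl)amino instead of 4-methylphenyl on the carbonyl carbon gives an at least 34-fold higher number from compound 2 to compound 4 (1.53 log units; beyond the scatter), so a methyl-bearing aromatic ring on this carbonyl does not by itself keep the lower number seen in this assay. The remaining step reads an at least 1.2-fold higher number from compound 3 to compound 4 (0.09 log units; that floor lies within the scatter), and that floor supports no order between these two compounds.

The compounds shown do not separate the effect of the amino link entering at the carbonyl carbon from that of the methyl's place on the ring; a plain phenylamino or a (4-methylphenyl)amino group on the same carbonyl would bear directly on this. From the compounds shown here alone, it also stays open whether the lower number of compound 2 extends to other groups on the benzoyl ring, such as methoxy or chloro, or survives a longer chain between the sulfur and the carbonyl.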